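The source may report more compounds than this note shows. Statements on the series, on what has been measured and on what is new or still open speak of the compounds shown alone.

Values in a functional assay (strain AB) with Danio rerio as the target, read by microscopy, with a stated time of 1 h; on this read-out higher numbers stand for an effect only at larger amounts of compound and lower numbers for an effect already at smaller amounts:
- compound 1 `CCN1CCc2c(sc(NC(=O)Nc3ccc(Cl)cc3)c2C(N)=O)C1`: 3120 nM
- compound 2 `CCN1CCc2c(sc(NC(=O)CN3CCCCC3)c2C(N)=O)C1`: > 25000 nM (a limit of the assay, not a number)
- compound 3 `CCN1CCc2c(sc(NC(=O)Nc3ccc(Br)cc3)c2C(N)=O)C1`: 3130 nM

Among the compounds with values here, compound 3 stands level with compound 1, the only other compound with a numeric value: a 1.0-fold higher number from compound 1 to compound 3 (0.00 log units; within the scatter). Compound 4 `CCN1CCc2c(sc(NC(=O)[C@@H]3CCCN3)c2C(N)=O)C1`, not yet measured, carries pyrrolidin-2-yl in place of (4-bromophenyl)amino on a carbonyl carbon.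

Two measured steps change the same carbonyl substituent, each replacing an aryl amino group with (piperidin-1-yl)methyl or the reverse: an at least 8.0-fold higher number from compound 1 to compound 2 (0.90 log units; beyond the scatter), and an at least 7.9-fold lower number from compound 2 to compound 3 (0.90 log units; beyond the scatter). Both lie beyond the scatter, but both rest on compound 2 alone, and their full size is open. Compound 4 also gives up the aryl amino group, so a clear rise in the number is expected, of about the size of those two steps, and a reading that reaches only a limit is quite possible. The expected step is a 6.4-fold higher number from compound 3 to compound 4 (0.81 log units; beyond the scatter). For compound 4 the estimate is 20000 nM, with an expected range of 6000 nM to 50000 nM.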

Compound 4, half-maximal effective concentration: > 25000 nM
Compound 4: only a limit was reported; the forecaster's own chance of this, stated with the estimate: 60%; at least 1.2-fold (0.09 log units) between middle value and limit.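

In this assay compound 4 gives > 25000 nM as a limit of the assay and not a number. From the compounds shown here alone, the rise on giving up the aryl amino group no longer rests on compound 2 alone: a second replacement on the carbonyl carbon, pyrrolidin-2-yl, gives an at least 7.9-fold higher number from compound 3 to compound 4 (0.90 log units; beyond the scatter) and an at least 8.0-fold higher number from compound 1 to compound 4 (0.90 log units; beyond the scatter) with the full size of both still open. Compound 2 and compound 4 cannot be read against each other, and they share the same ceiling: the limit of > 25000 nM in this assay, at which 2 of the 4 values shown sit.

Open, going by these compounds, is whether the halogen matters at all, which a plain phenylamino group on the carbonyl carbon would test. Also open, on these data alone, is whether a phenyl group attached directly to that carbonyl carbon, without the amino nitrogen, keeps a numeric reading.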